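Swapping the alpha substituent on a thromboxane synthase inhibitor

The source may hold more compounds than are shown below. What is called first, only, known or untested is meant among the compounds shown, and "the series" means these compounds.

Within the data shown here, compound 2 `COCC(CCC/C=C(\c1ccccc1)c1cccnc1)C(=O)O` is one of two compounds measured in an assay (Equus caballus) for inhibition of Thromboxane-A synthase (Homo sapiens), using microsomes; a higher number here means a weaker inhibitor, a lower number a stronger inhibitor. In this assay, among the measured compounds shown here, compound 2 gives 41 nM, while compound 1 `CSC(CCC/C=C(\c1ccccc1)c1cccnc1)C(=O)O` gives 30 nM; the only measured step, a 1.4-fold higher number from compound 1 to compound 2 (0.14 log units; within the scatter), is within the scatter, so the two numbers cannot be told apart. Compound 3 `O=C(O)C(CCC/C=C(\c1ccccc1)c1cccnc1)Sc1ccccc1` differs from compound 2 by phenylsulfanyl in place of methoxymethyl on a saturated chain carbon bound to a carbonyl carbon and a saturated chain carbon. For the measured compounds named here, the one measured step touches the same place in the molecule, exchanging methylsulfanyl for methoxymethyl, and it moved the number by a 1.4-fold higher number from compound 1 to compound 2 (0.14 log units; within the scatter), a change within the scatter. Going by the values given here, no measured step shows what bringing in a phenyl ring at this position does, so that part of the change is untested. The expectation for this assay is therefore no step beyond the scatter, with a wide range, and the estimated step is a 1.4-fold lower number from compound 2 to compound 3 (0.14 log units; within the scatter). Compound 3 is expected at 30 nM, between 8 nM and 120 nM.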

Compound 3, half-maximal inhibitory concentration: 33 nM
Compound 3: the middle estimate sits 1.1-fold (0.04 log units) below what was measured; the measured number falls inside the stated range.
By their numbers in this assay, from the lowest: compounds 1, 3 and 2 (each within the scatter of the next).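

Phenylsulfanyl brings a six-membered aromatic ring of carbon only, which neither earlier group has, and more heavy atoms than methoxymethyl, yet this assay shows a 1.2-fold lower number from compound 2 to compound 3 (0.09 log units; within the scatter) as the result of that swap. Changing only the group on the sulfur gives the cleaner comparison, and it shows a 1.1-fold higher number from compound 1 to compound 3 (0.04 log units; within the scatter) as the result of putting phenyl in place of methyl. On this saturated chain carbon bound to a carbonyl carbon and a saturated chain carbon, the three groups shown therefore give numbers that cannot be told apart, and nothing available explains why.

Still open, going by these compounds, is how an amine or a hydroxyl group on this same carbon would read. On these data alone, a longer chain carrying the phenyl ring, such as benzylsulfanyl, is also open.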